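Lengthening an Amide Chain on a Shared Core

The source may report more compounds than this note shows. Statements on the series, on what has been measured and on what is new or still open speak of the compounds shown alone.

Three compounds with the same core and an amide side chain of growing length have been tested in an ADME assay on Vero cells (Chlorocebus sabaeus) for cytotoxicity; on this read-out lower numbers stand for higher toxicity in this test and higher numbers for lower toxicity in this test. Compound 1 `CC(=O)Nc1nc(N)nc2c1ncn2[C@H]1CO[C@@H](CO)O1` carries the shortest chain. In this assay compound 1 reaches only the limit of the assay, > 100000 nM. Compound 2 `CCCC(=O)Nc1nc(N)nc2c1ncn2[C@H]1CO[C@@H](CO)O1` differs from compound 1 by ethyl in place of hydrogen on a saturated chain carbon bound to a carbonyl carbon. In this assay compound 2 likewise reaches only the limit, > 100000 nM. Both sit at the limit of > 100000 nM in this assay, at which 2 of the 3 values shown sit, so the step that the two limits leave unreadable from compound 1 to compound 2 cannot be read. Compound 3 `CCCCCCCCCCCC(=O)Nc1nc(N)nc2c1ncn2[C@H]1CO[C@@H](CO)O1` differs from compound 1 by decyl in place of hydrogen on a saturated chain carbon bound to a carbonyl carbon. In this assay, going by the values given here, compound 3 gives 53000 nM, the only number in the set. From this follow an at least 1.8-fold lower number from compound 1 to compound 3 (0.27 log units; that floor lies within the scatter) and an at least 1.8-fold lower number from compound 2 to compound 3 (0.27 log units; that floor lies within the scatter).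

Compound 4 `CCCCCCCCCCCCCC(=O)Nc1nc(N)nc2c1ncn2[C@H]1CO[C@@H](CO)O1` has not yet been measured. It differs from compound 3 by ethyl in place of hydrogen on a saturated chain carbon, ten or more bonds along the chain from a carbonyl carbon. This is the same kind of change as that from compound 1 to compound 2, with the same group entering, but the place differs, as the two descriptions of the differences show: in the first pair the ethyl enters on a saturated chain carbon bound to a carbonyl carbon, in the second it does not. The two cores of the pairs differ by decyl in place of hydrogen on a saturated chain carbon bound to a carbonyl carbon. The earlier instance of the change gave no readable step, and the only readable direction in the set is that compound 3 sits at a number while the shorter chains sit at a limit. For compound 4 the expected step is therefore a 1.3-fold lower number from compound 3 to compound 4 (0.12 log units; within the scatter), a small one that stays within the usual scatter. The expected value for compound 4 is 40000 nM, with a range from 15000 nM to 100000 nM.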

Compound 4, half-maximal cytotoxic concentration: 7700 nM
The estimate for compound 4 lay 5.2-fold (0.72 log units) above the measured number; measured number outside the range, below it.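

In this assay, the ethyl change now gives a readable result on a long chain: a 6.9-fold lower number from compound 3 to compound 4 (0.84 log units; beyond the scatter), whereas the step on the shortest chain cannot be read. The decyl change gives an at least 12-fold lower number from compound 2 to compound 4 (1.11 log units; beyond the scatter), and it can be set beside its earlier instance on a different core: the same change on two cores in this assay, an at least 1.8-fold lower number (0.27 log units; that floor lies within the scatter) from compound 1 to compound 3 and an at least 12-fold lower number (1.11 log units; beyond the scatter) from compound 2 to compound 4; the limit leaves it open whether they differ This shows a clear drop on the core of compound 2, but it does not show that the change acts more strongly on one core than on the other, and its size cannot simply be carried from one core to the next, because the shorter chains give no actual number: the limit of > 100000 nM in this assay, at which 2 of the 4 values shown sit.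

The compounds shown leave open whether a still longer chain would lower the number further, and whether a branched chain, or a chain ending in an amine or a carboxylic acid, would follow the same course. They also leave open how far the trend seen from compound 3 to compound 4 would extend beyond these straight chains on the shared core.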